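The compounds below may be only part of what the source reports. "The series", "measured", "known", "first", "only" and "open" are said of these compounds alone.

In a functional assay on KB-C2 cells (Homo sapiens) for cytotoxicity, read by MTT assay, with a stated time of 48 h, in the presence of a further agent that is not named here (a lower number here means a stronger inhibitor, a higher number a weaker inhibitor), compound 1 `C=C[C@@]1(C)COC(=O)[C@]12OC([C@H](C)CC)=CC2=O` gives 70.8 ug/mL, within the scatter of compound 2 `C=C[C@@]1(C)COC(=O)C1(O)C(=O)/C=C(\O)c1ccccc1` at 53.1 ug/mL, while compound 3 `C=C[C@@]1(C)COC(=O)C1C(=O)/C=C(\O)c1ccccc1` gives a lower number, 24.6 ug/mL. Compound 4 `C=C[C@@]1(C)COC(=O)[C@]12OC(c1ccccc1)=CC2=O` keeps the core of compound 1 and changes one group: phenyl in place of sec-butyl on a double-bonded ring carbon. Among the compounds with values here, the only measured step, a 2.2-fold lower number from compound 2 to compound 3 (0.33 log units; beyond the scatter), is modest and concerns hydrogen in place of hydroxy, so it does not test this swap directly. Compounds 2 and 3 both carry a phenyl, but neither has a sec-butyl partner for comparison. A step beyond the scatter is therefore not expected, and the estimated change is a 1.6-fold lower number from compound 1 to compound 4 (0.20 log units; within the scatter). For compound 4 the expected value is 45 ug/mL, with an estimated range from 18 ug/mL to 100 ug/mL.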

Compound 4, half-maximal inhibitory concentration: 51.8 ug/mL
Estimate against measurement, compound 4: 1.2-fold (0.06 log units) below; the range from low to high includes it.
By their numbers in this assay, from the lowest: compound 3; then compounds 4, 2 and 1 (each within the scatter of the next).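

Placing phenyl in place of sec-butyl on this double-bonded ring carbon gives a 1.4-fold lower number from compound 1 to compound 4 (0.14 log units; within the scatter) in this assay, so a six-membered aromatic ring and a branched chain without a ring read alike at this position. Within the data shown here, this is the first direct reading of a change here, as the earlier step concerned hydrogen in place of hydroxy. Nothing available explains this result.

On these data alone, whether an amine, a carboxylic acid or a longer chain on this carbon would move the number beyond the scatter remains open.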